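A few compounds are considered here, and "the series" means these few. Any claim that something is new, unique, unknown or untested is made for them only; others in the source may bear on it.

- Compound 1 `CC(C)(C)OC(=O)CCCN1CCc2c(sc(NC(=O)Nc3ccc(Cl)cc3)c2C(N)=O)C1`: 560 nM
- Compound 2 `CC(C)(C)OC(=O)CCCCN1CCc2c(sc(NC(=O)Nc3ccc(Cl)cc3)c2C(N)=O)C1`: 710 nM

Going by the values given here, in a functional assay (strain AB) with Danio rerio as the target, read by microscopy, with a stated time of 1 h (a higher number here means that more compound is needed for the effect, a lower number that less compound is needed), compound 2 at 710 nM lies within the scatter of compound 1, the only other compound measured. Compound 3 `CC(C)(C)OC(=O)CCCCCN1CCc2c(sc(NC(=O)Nc3ccc(Cl)cc3)c2C(N)=O)C1` differs from it as follows: (tert-butoxycarbonyl)methyl in place of tert-butoxycarbonyl on a saturated chain carbon, four bonds along the chain from an amine nitrogen in a ring. (tert-Butoxycarbonyl)methyl replaces tert-butoxycarbonyl on a saturated chain carbon, four bonds along the chain from an amine nitrogen in a ring. Among the compounds with values here, the only measured step of this kind, the same replacement three bonds along the chain, is a 1.3-fold higher number from compound 1 to compound 2 (0.10 log units; within the scatter). Nothing beyond the scatter is therefore expected in this assay. The expected step is a 1.1-fold higher number from compound 2 to compound 3 (0.05 log units; within the scatter). Compound 3 is estimated at 800 nM, with an expected range of 350 nM to 1800 nM.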

Compound 3, half-maximal effective concentration: 620 nM
Estimate against measurement, compound 3: 1.3-fold (0.11 log units) above, and the stated range covers the measured number.
By their numbers in this assay, from the lowest: compounds 1, 3 and 2 (each within the scatter of the next).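

In this assay, the same replacement one bond further along the chain again stays within the scatter, with a 1.1-fold lower number from compound 2 to compound 3 (0.06 log units; within the scatter). The larger change, 2-(tert-butoxycarbonyl)ethyl in place of tert-butoxycarbonyl, also gives only a 1.1-fold higher number from compound 1 to compound 3 (0.04 log units; within the scatter), so the three chain lengths shown cannot be told apart at this position. No evidence is available to explain this.

As far as these compounds go, whether a longer chain would stay within this range remains open. So does whether a carboxylic acid or an amine in place of the tert-butyl ester would leave the number unchanged.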